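Truncation of the distal aryl group in a benzyl amide series

The compounds below may be only part of what the source reports. "The series", "measured", "known", "first", "only" and "open" are said of these compounds alone.

Measured compounds:
- compound 1 `COC(=O)/C=C/c1cccc(N(Cc2ccc(/C=C/c3cccc(F)c3)cc2)C(=O)C2CCCCC2)c1`: 86 nM
- compound 2 `COC(=O)/C=C/c1cccc(N(Cc2ccc(-c3cccc(C)c3)cc2)C(=O)C2CCCCC2)c1`: 109 nM

Both compounds were tested in an assay on isolated protein with Bile acid receptor (Homo sapiens) as the target; a lower number here means that less compound is needed, a higher number that more compound is needed for the effect. Compound 2 gives 109 nM and stands with the highest number of the two, yet its nearest neighbour compound 1 differs by a 1.3-fold higher number from compound 1 to compound 2 (0.10 log units; within the scatter), so the pair is indistinguishable.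

Compound 3 `COC(=O)/C=C/c1cccc(N(Cc2ccccc2)C(=O)C2CCCCC2)c1` is the truncated analogue: hydrogen in place of 3-methylphenyl on an aromatic carbon. Among the compounds with values here, the only measured step, from compound 1 to compound 2, exchanges one distal aryl unit for another and is within the scatter; it says nothing about removing that unit altogether. Within the data shown here, no measured step bears directly on the change to compound 3. Loss of the whole group para to a large group is expected to cost potency, so a clear increase in the number is expected for compound 3, a 9.2-fold higher number from compound 2 to compound 3 (0.96 log units; beyond the scatter). Compound 3 is estimated at 1000 nM, with a range of 250 nM to 5000 nM.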

Compound 3, half-maximal effective concentration: > 1000 nM
Compound 3: a limit, no number; the forecaster's own chance of this, stated with the estimate: 20%; the middle value sits exactly at the limit.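

In this assay compound 3 gives > 1000 nM, which is a limit of the assay and not a number. Exchanging one distal aryl unit for another stayed within the scatter (a 1.3-fold higher number from compound 1 to compound 2 (0.10 log units; within the scatter)), whereas replacing the unit with hydrogen gives an at least 9.1-fold higher number from compound 2 to compound 3 (0.96 log units; beyond the scatter) and an at least 11-fold higher number from compound 1 to compound 3 (1.06 log units; beyond the scatter). The aromatic carbon para to a large group therefore accepts either 3-methylphenyl or 2-(3-fluorophenyl)ethenyl, but hydrogen there costs potency, and the full size of that loss stays unresolved: the limit of > 1000 nM in this assay, at which 1 of the 3 values shown sits.

Open, on these data alone, is how much of the distal unit is required: whether a methyl group or an unsubstituted phenyl on this carbon keeps the number near that of compound 2 cannot be told from these compounds. Also open, as far as these compounds go, is whether the same dependence holds with a carboxylic acid in place of the methyl ester.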